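The source may hold more compounds than are shown below. What is called first, only, known or untested is meant among the compounds shown, and "the series" means these compounds.

Of the compounds shown here, three built on one shared core have been measured. Compound 1 `Cc1cc(C(=O)O)nn1Cc1cc(Br)ccc1OCc1ccccc1` carries a carboxylic acid, compound 2 `Cc1cc(C(N)=O)nn1Cc1cc(Cl)ccc1OCc1ccccc1` a primary amide, and compound 3 `Cc1cc(C(=O)Nc2cccc(F)c2)nn1Cc1cc(Cl)ccc1OCc1ccccc1` an amide bearing a 3-fluorophenyl group. In a physicochemical assay for lipophilicity, at pH 7.4 (a higher number here means a more lipophilic compound, a lower number a more polar compound), compound 1 gives 1.2, compound 2 gives 3.7, and compound 3 gives 2.8. Among these three numbers compound 3 stands second highest, closest to compound 2 and furthest from compound 1. Within the data shown here, the only step between two compounds differing in one place is a number 0.90 log units lower from compound 2 to compound 3 (beyond the scatter).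

Compound 4 `Cc1cc(C(=O)Nc2ccccn2)nn1Cc1cc(Cl)ccc1OCc1ccccc1` differs from compound 3 by pyridin-2-yl in place of 3-fluorophenyl on an amide-type nitrogen. Among the measured compounds shown here, no measured step exchanges one aromatic ring for another on the amide nitrogen, so the step from compound 2 to compound 3 bears on this change only indirectly, by showing the size of change this assay registers at that position. Since the entering group brings one hydrogen-bond acceptor where the leaving group has none, a moderate fall beyond the scatter is expected, estimated as a number 0.70 log units lower from compound 3 to compound 4 (beyond the scatter). Compound 4 is therefore expected to give 2.1, within a range from 1.4 to 2.8.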

Compound 4, distribution coefficient: > 3.7
Compound 4 gave a limit, no number; the forecaster's own chance of this, stated with the estimate: 0%; middle value at least 1.60 log units away from the limit.
By their numbers in this assay, from the lowest: compound 1; then compound 3; then compound 2.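

In this assay compound 4 gives > 3.7, which is a limit of the assay and not a number: the limit of > 3.7 in this assay, at which 1 of the 4 values shown sits. Pyridin-2-yl in place of 3-fluorophenyl on an amide-type nitrogen gives a number at least 0.90 log units higher from compound 3 to compound 4 (beyond the scatter), so exchanging one aromatic ring for another moves this read-out at this position, and the ring with the hydrogen-bond acceptor carries the higher result. The size of the remaining step cannot be read: a number no lower from compound 2 to compound 4 (the limit leaves the size open).

The compounds shown leave open how far the result for compound 4 lies past the limit, and whether the step follows the ring nitrogen or the loss of the fluorine. From the compounds shown here alone, what phenyl or pyridin-3-yl on the same nitrogen would give also stays open.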